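A few compounds are considered here, and "the series" means these few. Any claim that something is new, unique, unknown or untested is made for them only; others in the source may bear on it.

Three compounds share one core and differ only in the aromatic group attached to it. Compound 1 `COc1cc2c(Oc3ccc(NC(=O)c4cc(-c5cccc(Cl)c5)nc5ccccc45)cc3F)ccnc2cc1OCCCN1CCC(C)CC1` carries a 3-chlorophenyl group, and in a functional assay on MKN-45 cells (Homo sapiens) for cytotoxicity, read by MTT assay, with a stated time of 72 h (on this read-out higher numbers stand for weaker inhibition and lower numbers for stronger inhibition), compound 1 gives 30 nM. Compound 2 `COc1ccc(-c2cc(C(=O)Nc3ccc(Oc4ccnc5cc(OCCCN6CCC(C)CC6)c(OC)cc45)c(F)c3)c3ccccc3n2)cc1` carries a 4-methoxyphenyl group in that place, and in this assay compound 2 gives 320 nM. Compound 3 `COc1cc2c(Oc3ccc(NC(=O)c4cc(-c5ccc(C)cc5)nc5ccccc45)cc3F)ccnc2cc1OCCCN1CCC(C)CC1` carries a 4-methylphenyl group, and in this assay compound 3 gives 770 nM, the highest of the three numbers and so the weakest inhibition among them. The steps of an 11-fold higher number from compound 1 to compound 2 (1.03 log units; beyond the scatter) and a 26-fold higher number from compound 1 to compound 3 (1.41 log units; beyond the scatter) are both large, while a 2.4-fold higher number from compound 2 to compound 3 (0.38 log units; beyond the scatter) is modest.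

Compound 4 `COc1cc2c(Oc3ccc(NC(=O)c4cc(-c5ccc(C)cc5)nc5ccccc45)cc3F)ccnc2cc1OCCCN1CCCC1` keeps the 4-methylphenyl group of compound 3 and changes the far end of the molecule instead: pyrrolidin-1-yl in place of 4-methylpiperidin-1-yl on a saturated chain carbon, three bonds along the chain from an oxygen on an aromatic ring. None of the three measured steps touches this part of the structure; each of them varies only the aromatic group. Among the compounds with values here, there is therefore no measured step that bears directly on this change, and nothing in the numbers points to a particular direction. The step of a 1.0-fold higher number from compound 3 to compound 4 (0.02 log units; within the scatter) is expected to stay within the scatter. Compound 4 is estimated at 800 nM, with a range from 250 nM to 2500 nM.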

Compound 4, half-maximal inhibitory concentration: 300 nM
Estimate against measurement, compound 4: 2.7-fold (0.43 log units) above, within the range that was stated.
By their numbers in this assay, from the lowest: compound 1; then compounds 4 and 2 (each within the scatter of the next); then compound 3.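

Within the data shown here, the far end of the chain matters as well: with the 4-methylphenyl group held constant in this assay, pyrrolidin-1-yl in place of 4-methylpiperidin-1-yl gives a 2.6-fold lower number from compound 3 to compound 4 (0.41 log units; beyond the scatter) and so a modest gain in inhibition, whereas the earlier steps spoke only to the aromatic group. This single step changes two things together, since the five-membered ring replaces a six-membered one and the methyl group is lost, so the data cannot assign the shift to either change. Nothing here offers an explanation for the shift, so the result stands as an observation without a known cause.

A compound with plain piperidin-1-yl at the end of the propyl chain would separate the effect of ring size from that of the methyl group, while morpholin-4-yl or dimethylamino would show how far the trend reaches beyond these two rings. As far as these compounds go, it also remains open whether pyrrolidin-1-yl has a similar effect alongside the 3-chlorophenyl group of compound 1, since this step was read only with the 4-methylphenyl group in place.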